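A few compounds are considered here, and "the series" means these few. Any claim that something is new, unique, unknown or untested is made for them only; others in the source may bear on it.

Working notes on a physicochemical assay for lipophilicity, at pH 7.4 (on this read-out higher numbers stand for higher lipophilicity and lower numbers for lower lipophilicity), for this series. Of the compounds shown here, three have numbers so far. Compound 1 `CNC(=O)c1cc(C(=O)NCCCC2CNCCO2)cn(Cc2ccccc2)c1=O` gives 1.4 in this assay, the lowest of the three. Compound 2 `CNC(=O)c1cc(C(=O)NC2CC2)cn(CC2CCCOC2)c1=O` gives 2 in this assay, the nearest number to compound 1 and still beyond the scatter. Compound 3 `CNC(=O)c1cc(C(=O)NC2CC2)c(C)n(Cc2ccccc2)c1=O` gives 2.9 in this assay, the furthest from compound 1, also beyond the scatter. Among the compounds with values here, no two of these three differ in one place only, so no single-point step in this assay is known from them, and the values of compounds 2 and 3 can only be read as what they are.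

Compound 4 `CNC(=O)c1cc(C(=O)NC2CCOCC2)cn(Cc2ccccc2)c1=O` has no number yet. It differs from compound 1 in one place: oxan-4-yl in place of 3-(morpholin-2-yl)propyl on an amide-type nitrogen. The group that leaves brings one hydrogen-bond donor and two hydrogen-bond acceptors; the group that enters brings no hydrogen-bond donor and one hydrogen-bond acceptor, and is smaller by three heavy atoms.

Within the data shown here, with no measured pair sharing this change, the size of the step rests on expectation alone. An upward move in this assay is expected, beyond the scatter: the estimated step is a number 0.80 log units higher from compound 1 to compound 4 (beyond the scatter). For compound 4 the estimate in this assay is 2.2, with an expected range from 1.7 to 2.7.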

Compound 4, distribution coefficient: 2.8
Estimate against measurement, compound 4: 0.60 log units below; measured number above the stated range.
By their numbers in this assay, from the lowest: compound 1; then compound 2; then compounds 4 and 3 (each within the scatter of the next).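

Oxan-4-yl in place of 3-(morpholin-2-yl)propyl on the amide-type nitrogen gives the first single-place step in this assay for this series: a number 1.40 log units higher from compound 1 to compound 4 (beyond the scatter), a large move that shows the read-out responds strongly to the group at this position. This one step combines several differences, since the group that leaves has 9 heavy atoms, 1 hydrogen-bond donor and 2 hydrogen-bond acceptors, and the group that enters has 6 heavy atoms, 0 hydrogen-bond donors and 1 hydrogen-bond acceptor. No measurement here accounts for the size of the step or assigns it to any one of these differences.

The compounds shown do not separate the contribution of the propyl chain from that of the ring nitrogen, a question that a propyl chain ending in an oxane ring, or a morpholine ring carried directly on the amide nitrogen, would bear on. From the compounds shown here alone, it also remains open how far the number would move with a plain acyclic amine or a carboxylic acid at the end of the same chain, and whether a step of this size holds on other versions of the shared core.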